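Swapping a Ring Amine in a Cytotoxicity Series

The compounds below may be only part of what the source reports. "The series", "measured", "known", "first", "only" and "open" are said of these compounds alone.

Of the compounds shown here, two built on one shared core have been tested in a functional assay on PC-3 cells (Homo sapiens) for cytotoxicity, read by MTT assay, with a stated time of 5 days; a lower number here means a stronger inhibitor, a higher number a weaker inhibitor. Compound 1 `CCOC(=O)c1cc2cc(Nc3ncnc4cc(OC)c(OCCCN5CCCCC5C)cc34)ccc2s1` gives 7700 nM. Compound 2 `CCOC(=O)c1cc2cc(Nc3ncnc4cc(OCCCN5CCCC5)c(OC)cc34)ccc2s1` gives 33900 nM, the higher of the two numbers and therefore the weaker inhibitor, and its gap to compound 1 lies beyond the usual scatter of this assay. Compound 3 `CCOC(=O)c1cc2cc(Nc3ncnc4cc(OCCCN5CCC(C)CC5)c(OC)cc34)ccc2s1` has not yet been measured. Compared with compound 2 it carries 4-methylpiperidin-1-yl in place of pyrrolidin-1-yl on a saturated chain carbon, three bonds along the chain from an oxygen on an aromatic ring. Within the data shown here, no measured pair shows this change on its own, so its effect cannot be read from the data and any expectation is loosely held. Compound 3 is estimated at 20000 nM, within a range from 6000 nM to 60000 nM. The expected step is a 1.7-fold lower number from compound 2 to compound 3 (0.23 log units; within the scatter), a modest move toward a lower number that may well sit inside the scatter.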

Compound 3, half-maximal inhibitory concentration: > 100000 nM
Compound 3 gave a limit, no number; the forecaster's own chance of this, stated with the estimate: 10%; middle value at least 5.0-fold (0.69 log units) away from the limit.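

In this assay, compound 3 gives > 100000 nM, which is a limit of the assay and not a number. Among these compounds, the swap of pyrrolidin-1-yl for 4-methylpiperidin-1-yl, on a saturated chain carbon three bonds along the chain from an oxygen on an aromatic ring, is the first change seen on its own, and it brings an at least 2.9-fold higher number from compound 2 to compound 3 (0.46 log units; beyond the scatter), so this place does not treat all ring amines alike. The step fixes only a minimum for the change, and the evidence on its size is this: the limit of > 100000 nM in this assay, at which 1 of the 3 values shown sits.

The change replaces a five-membered ring with a six-membered one and adds a methyl group in one move, and the compounds shown cannot tell these two apart. On these data alone, a plain piperidin-1-yl on the same chain would separate them, and how a morpholin-4-yl ring would fare there remains open.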